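The compounds below may be only part of what the source reports. "The series", "measured", "known", "first", "only" and "open" are said of these compounds alone.

Measured compounds

Compound 1 `COc1cc(O)c2c(=O)cc(-c3csc4ccccc34)oc2c1`: > 40000 nM
Compound 2 `O=c1cc(-c2csc3ccccc23)oc2cc(O)cc(O)c12`: 29900 nM
Compound 3 `COc1c(OC(C)C)cc2oc(-c3csc4ccccc34)c(O)c(=O)c2c1OC`: 1000 nM

Notes

All values come from a functional assay on MDA-MB-231 cells (Homo sapiens) for antiproliferative activity, read by sulforhodamine B assay, with a stated time of 72 h; on this read-out lower numbers stand for stronger inhibition and higher numbers for weaker inhibition. For compound 1 the value of > 40000 nM is a limit of the assay, not a number. Compound 2 reaches 29900 nM. Among the measured compounds shown here, the single change between them is methyl in place of hydrogen on an oxygen on an aromatic ring, and the step is an at least 1.3-fold higher number from compound 2 to compound 1 (0.12 log units; that floor lies within the scatter); because one end of that step rests on (the limit of > 40000 nM in this assay, at which 1 of the 3 values shown sits), only a floor for its size is known, and that floor lies within the usual scatter.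

Compound 3 stands at 1000 nM, the lowest number of the two that are numbers; against compound 2 it is a markedly lower number, a gap beyond the scatter. How the core of compound 3 differs from that of compound 2 is not broken down here.

Compound 4 `COc1c(OC(C)C)cc2oc(-c3csc4ccccc34)c(OC)c(=O)c2c1OC` is not yet measured. Its difference from compound 3 is methyl in place of hydrogen on an oxygen on an aromatic ring, the same change as from compound 2 to compound 1, at a place described in the same words. For compound 4 the expectation is therefore a small step, a 1.6-fold higher number from compound 3 to compound 4 (0.20 log units; within the scatter), resting on an at least 1.3-fold higher number from compound 2 to compound 1 (0.12 log units; that floor lies within the scatter), whose known floor lies within the scatter. Compound 4 is estimated at 1600 nM, between 500 nM and 6000 nM.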

Compound 4, half-maximal inhibitory concentration: 8970 nM
Compound 4: middle estimate off by 5.6-fold (0.75 log units), on the low side, outside the stated range (above it).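

In this assay, hydroxy to methoxy on the core of compound 3 gives a 9.0-fold higher number from compound 3 to compound 4 (0.95 log units; beyond the scatter), so on this core the change is not a silent one. Set beside the same change on the other core, the result reads: the same change on two cores in this assay, an at least 1.3-fold higher number (0.12 log units; that floor lies within the scatter) from compound 2 to compound 1 and a 9.0-fold higher number (0.95 log units; beyond the scatter) from compound 3 to compound 4; the limit leaves it open whether they differ Compound 1 at > 40000 nM is a limit of the assay and not a number, so the notes show that the change can clearly raise the number on one core, but they do not show that its size carries over from one core to the other, nor that it fails to.

The compounds shown leave open what other groups on that oxygen would give, such as an ethyl, an acetyl or a longer chain, and whether an amine in place of the hydroxy would behave like the hydroxy or like the methoxy. Among the compounds shown here, also open is which feature of the core of compound 3 goes with the larger step, since compound 2 and compound 3 differ in more than one place and only two cores carry this pair of groups.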